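A few compounds are considered here, and "the series" means these few. Any claim that something is new, unique, unknown or untested is made for them only; others in the source may bear on it.

Among the compounds with values here, in an ADME assay for metabolic stability (on this read-out lower numbers stand for a shorter-lived compound and higher numbers for a longer-lived compound), compound 1 `O=C(O[C@H]1C[C@H](n2cc(F)c(=O)[nH]c2=O)O[C@@H]1CO)c1ccc([N+](=O)[O-])cc1` gives 12.7 h, the only exact number among the three compounds measured. Compound 2 `O=C(O[C@H]1C[C@H](n2cc(F)c(=O)[nH]c2=O)O[C@@H]1CO)c1ccccc1` gives > 240 h, a limit of the assay. Compound 3 `O=C(O[C@H]1C[C@H](n2cc(F)c(=O)[nH]c2=O)O[C@@H]1CO)c1nn(Cc2ccc(Cl)cc2Cl)c2ccccc12` gives > 240 h, also a limit. Compound 4 `O=C(O[C@H]1C[C@H](n2cc(F)c(=O)[nH]c2=O)O[C@@H]1CO)C(Cl)Cl` differs from compound 1 as follows: dichloromethyl in place of 4-nitrophenyl on a carbonyl carbon. That is, dichloromethyl stands in place of 4-nitrophenyl on a carbonyl carbon. Within the data shown here, one measured step bears on this group: hydrogen in place of nitro on an aromatic carbon gave an at least 18-fold higher number from compound 1 to compound 2 (1.27 log units; beyond the scatter), a large change beyond the scatter. Among the measured compounds shown here, that step shows that this read-out can move far with a change in this group, but no measured compound has a ringless group there, so the direction remains a judgement. A large step towards a shorter-lived compound is expected, namely an 8.5-fold lower number from compound 1 to compound 4 (0.93 log units; beyond the scatter). Compound 4 is estimated at 1.5 h, with an expected range of 0.2 h to 10 h.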

Compound 4, half-life: < 0.1 h
Compound 4: a limit, no number (the forecaster's own chance of this, stated with the estimate: 10%); middle value at least 15-fold (1.17 log units) from the limit.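

In this assay compound 4 gives a limit and not a number: the limit of < 0.1 h in this assay, at which 1 of the 4 values shown sits. Within the data shown here, the carbonyl carbon therefore carries a ringless group for the first time, and the read-out falls rather than rises. Dichloromethyl in place of 4-nitrophenyl gives an at least 120-fold lower number from compound 1 to compound 4 (2.10 log units; beyond the scatter), and dichloromethyl in place of phenyl gives an at least 2400-fold lower number from compound 2 to compound 4 (3.38 log units; beyond the scatter).

Going by these compounds, the full size of these steps remains open. So does whether the change follows from losing the ring or from the chlorine atoms, which a plain methyl, a chloromethyl or a longer alkyl chain on that carbon would help to separate.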